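The compounds below may be only part of what the source reports. "The series", "measured", "known", "first", "only" and "open" are said of these compounds alone.

Measured so far in an assay on isolated protein for inhibition of Amine oxidase [flavin-containing] A (Homo sapiens); a higher number here means a weaker inhibitor, a lower number a stronger inhibitor:
compound 1 `CCN(CC)CCCOc1ccc(C(=O)/C=C/c2ccc(N(C)C)cc2)c(O)c1` gives 47100 nM;
compound 2 `CCN(CCCOc1ccc(C(=O)/C=C/c2ccc(N(C)C)cc2)c(O)c1)Cc1ccccc1` gives 82600 nM;
compound 3 `CCN(CCCCCCOc1ccc(C(=O)/C=C/c2ccc(N(C)C)cc2)c(O)c1)Cc1ccccc1N(C)C` gives 37800 nM.

Compound 2 stands at the highest number of the three: next to compound 1 it is within the scatter, while compound 3 lies beyond it with the lower number. Compound 4 `CCN(CCCOc1ccc(C(=O)/C=C/c2ccc(N(C)C)cc2)c(O)c1)Cc1ccccc1OC` differs from compound 2 by methoxy in place of hydrogen on an aromatic carbon, placed ortho to a large group. Going by the values given here, the only single-place step recorded, a 1.8-fold higher number from compound 1 to compound 2 (0.24 log units; within the scatter), concerns the benzyl group itself and was within the scatter; no step bears on substitution of that ring, and compound 3 differs in more than one place. The step from compound 2 to compound 4 is therefore expected to stay small, a 1.4-fold lower number from compound 2 to compound 4 (0.14 log units; within the scatter), with no clear direction. Compound 4 is estimated at 60000 nM, in the range 25000 nM to 150000 nM.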

Compound 4, half-maximal inhibitory concentration: 26300 nM
For compound 4 the middle estimate is 2.3-fold (0.36 log units) above the measured one, within the range that was stated.
By their numbers in this assay, from the lowest: compounds 4, 3, 1 and 2 (each within the scatter of the next, the first and the last beyond it).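

In this assay, going by these compounds alone, benzyl to 2-methoxybenzyl, with methoxy ortho to a large group, is the first single-place change to pass the scatter: a 3.1-fold lower number from compound 2 to compound 4 (0.50 log units; beyond the scatter). Against the diethylamino end of the series, however, a 1.8-fold lower number from compound 1 to compound 4 (0.25 log units; within the scatter), so the 2-methoxybenzyl group does not stand clear of the plain ethyl group. No measurement at hand accounts for the methoxy step.

Going by these compounds, whether fluorine, hydroxy or ethoxy at this same place would give a step of like size remains open. So does whether the methoxy step holds with a longer chain between the amine and the core.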